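Oxime-ether triazole analogues of a sesquiterpenoid ketone core

The source may hold more compounds than are shown below. What is called first, only, known or untested is meant among the compounds shown, and "the series" means these compounds.

Measured so far:
- compound 1 `CC(C)=CCC/C(C)=C/CC/C(C)=C/CC[C@@H]1[C@@]2(C)CCC(=O)C(C)(C)[C@@H]2CC[C@@]1(C)O`: 12000 nM
- compound 2 `COc1cccc(-n2cc(CO/N=C3\CC[C@]4(C)[C@@H](CC/C=C(\C)CC/C=C(\C)CCC=C(C)C)[C@](C)(O)CC[C@H]4C3(C)C)nn2)c1`: 21700 nM

In a functional assay on A549 cells (Homo sapiens) for cytotoxicity, read by MTT assay, with a stated time of 48 h (a lower number here means a stronger inhibitor, a higher number a weaker inhibitor), compound 1 gives 12000 nM and compound 2 gives 21700 nM; the two numbers lie within the scatter of each other, so neither stands apart. Compound 3 `CC(C)=CCC/C(C)=C/CC/C(C)=C/CC[C@@H]1[C@@]2(C)CC/C(=N\OCc3cn(-c4cccc(Br)c4)nn3)C(C)(C)[C@@H]2CC[C@@]1(C)O` is not yet measured. Compound 3 differs from compound 2 by bromo in place of methoxy on an aromatic carbon. Going by the values given here, no step between measured compounds of this kind is available, so the effect of the change is unknown. The step of a 1.2-fold lower number from compound 2 to compound 3 (0.08 log units; within the scatter) is expected to stay within the scatter. For compound 3 the estimate is 18000 nM with range 8000 nM to 40000 nM.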

Compound 3, half-maximal inhibitory concentration: 11700 nM
Compound 3: the middle estimate sits 1.5-fold (0.19 log units) above what was measured; the measured number falls inside the stated range.
By their numbers in this assay, from the lowest: compounds 3, 1 and 2 (each within the scatter of the next).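

In this assay, going by these compounds alone, the change from 3-methoxyphenyl to 3-bromophenyl gives a 1.9-fold lower number from compound 2 to compound 3 (0.27 log units; within the scatter) and so provides the first reading at this aromatic carbon of the series. Methoxy and bromo are not told apart here, so this exchange leaves the number within the scatter. No measured evidence bears on this result. From the compounds shown here alone, whether any group on this aromatic carbon moves the number beyond the scatter stays open. An amine or a carboxylic acid there would test this, and other places on the ring remain unread.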